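The source may hold more compounds than are shown below. What is called first, only, known or untested is meant among the compounds shown, and "the series" means these compounds.

Measured compounds:
compound 1 `ClCc1ccc(Cn2cnc3c(Cl)ncnc32)cc1` — 9330 nM
compound 2 `ClCc1ccccc1Cn1cnc2ncnc(Cl)c21` — > 100000 nM
compound 3 `ClCc1ccc(Cn2cnc3c(Cl)nc(Cl)nc32)cc1` — 42700 nM

In a functional assay on SF-268 cells (Homo sapiens) for cytotoxicity, read by sulforhodamine B assay, with a stated time of 48 h (on this read-out lower numbers stand for higher toxicity in this test and higher numbers for lower toxicity in this test), compound 1 gives 9330 nM. Compound 3 differs from compound 1 by chloro in place of hydrogen on an aromatic carbon, and this change made a 4.6-fold higher number from compound 1 to compound 3 (0.66 log units; beyond the scatter), meaning lower toxicity. For compound 2 the read-out is only a limit, not a number: it reached (the limit of > 100000 nM in this assay, at which 1 of the 3 values shown sits). How the core of compound 2 differs from the core of compound 1 is not broken down here.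

Compound 4 `ClCc1ccccc1Cn1cnc2nc(Cl)nc(Cl)c21` has not been measured. It differs from compound 2 by chloro in place of hydrogen on an aromatic carbon, which is the same change, at the same place, as from compound 1 to compound 3. Because that change gave a 4.6-fold higher number from compound 1 to compound 3 (0.66 log units; beyond the scatter), adding chloro is expected to leave the number at or beyond the limit. Compound 4 is therefore estimated at 200000 nM, an expected step that the limit leaves unreadable from compound 2 to compound 4, most likely reported again only as a limit.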

Compound 4, concentration lethal to 50% of the cells: > 100000 nM
Compound 4: no number, only a limit (the forecaster's own chance of this, stated with the estimate: 85%); the middle value is on the limit's open side.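

Compound 2 and compound 4 both give only a limit in this assay, so no step can be read between them: the limit of > 100000 nM in this assay, at which 2 of the 4 values shown sit.

The compounds shown leave open whether chloro in place of hydrogen changes the number at all on the core of compound 2.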